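The compounds below may be only part of what the source reports. "The series", "measured", "known", "first", "only" and "open" are said of these compounds alone.

Among the compounds with values here, in a functional assay on KB cells (Homo sapiens) for inhibition (on this read-out higher numbers stand for weaker inhibition and lower numbers for stronger inhibition), compound 1 (`COC[C@H]1OC(n2c(Cl)nc3cc(Cl)c(Cl)cc32)[C@H](O)[C@@H]1O`) gives 90000 nM, and compound 2 (`[N-]=[N+]=NC[C@H]1OC(n2c(Cl)nc3cc(Cl)c(Cl)cc32)[C@H](O)[C@@H]1O`) gives 70000 nM, so compound 2 stands level with the only other measured compound. Compound 3 (`CSC[C@H]1OC(n2c(Cl)nc3cc(Cl)c(Cl)cc32)[C@H](O)[C@@H]1O`) carries methylsulfanyl in place of azido on a saturated chain carbon bound to a saturated ring carbon. Within the data shown here, the one measured step at this place, a 1.3-fold lower number from compound 1 to compound 2 (0.11 log units; within the scatter), is small, so no shift beyond the scatter is expected in this assay. The expected step is a 1.1-fold higher number from compound 2 to compound 3 (0.06 log units; within the scatter). Compound 3 is estimated at 80000 nM, with an expected range of 35000 nM to 170000 nM.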

Compound 3, half-maximal inhibitory concentration: > 100000 nM
Compound 3 gave a limit, no number (the forecaster's own chance of this, stated with the estimate: 15%); middle value at least 1.2-fold (0.09 log units) away from the limit.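

In this assay compound 3 gives only a limit, not a number: the limit of > 100000 nM in this assay, at which 1 of the 3 values shown sits. Methylsulfanyl in place of azido gives an at least 1.4-fold higher number from compound 2 to compound 3 (0.15 log units; that floor lies within the scatter), and methylsulfanyl in place of methoxy gives an at least 1.1-fold higher number from compound 1 to compound 3 (0.04 log units; that floor lies within the scatter). So a third group on this saturated chain carbon brings no stronger inhibition, although neither floor separates it from the other two groups.

On these data alone, how far the true number of compound 3 lies past its limit stays open. So does whether an amine or a hydroxyl at this place would give a clearly lower number.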